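The source may hold more compounds than are shown below. What is called first, only, known or untested is meant among the compounds shown, and "the series" means these compounds.

Measured so far:
Compound 1 `Cc1cc(C)c(CN2CCc3c(Cl)cc([C@@H](C)CO)c(Cl)c3C2=O)c(=O)[nH]1` — 1040 nM
Compound 2 `Cc1cc(C)c(CN2CCc3c(Cl)cc([C@H](CO)[C@@H]4CCCO4)c(Cl)c3C2=O)c(=O)[nH]1` — 41 nM
Compound 3 `Cc1cc(C)c(CN2CCc3c(Cl)cc(C(CO)C4CCOC4)c(Cl)c3C2=O)c(=O)[nH]1` — 1010 nM; 15 nM (2 entries)

In an assay on cells for inhibition of histone-lysine N-methyltransferase EZH2 (Homo sapiens), read by ELISA, with a stated time of 72 h (a lower number here means a stronger inhibitor, a higher number a weaker inhibitor), compound 2 stands at the lowest of the two single numbers, with compound 1 giving a number a long way higher; compound 3 has no single number, since its repeat entries spread widely (the several entries of compound 3 in this assay, 1010 nM; 15 nM (2 entries)). Within the data shown here, the one measured step runs from compound 1 to compound 2, where oxolan-2-yl replaces methyl on the saturated chain carbon bound to the aromatic ring and gives a 25-fold lower number from compound 1 to compound 2 (1.40 log units; beyond the scatter).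

Compound 4 `Cc1cc(C)c(CN2CCc3c(Cl)cc([C@H](C)CO)c(Cl)c3C2=O)c(=O)[nH]1` has not been measured. It differs from compound 2 by a group of 4 heavy atoms (3 carbon, 1 oxygen; no ring) in place of a group of 8 heavy atoms (6 carbon, 2 oxygen; one five-membered non-aromatic ring with 1 hetero atom), on an aromatic carbon. This is essentially the reverse of the measured step, so the expectation is a rise of similar size, back toward the level of compound 1, though the spread seen for compound 3 the several entries of compound 3 in this assay, 1010 nM; 15 nM (2 entries) warns that the number may land well off that mark. The estimated step is a 24-fold higher number from compound 2 to compound 4 (1.39 log units; beyond the scatter), and compound 4 is expected to give 1000 nM in this assay, within a range from 250 nM to 4000 nM.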

Compound 4, half-maximal inhibitory concentration: 129 nM
Compound 4: the middle estimate sits 7.8-fold (0.89 log units) above what was measured; measured number below the stated range.
By their numbers in this assay, from the lowest: compound 2; then compound 4; then compound 1.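

In this assay, the configuration at the saturated chain carbon bound to the aromatic ring matters by itself, giving an 8.1-fold lower number from compound 1 to compound 4 (0.91 log units; beyond the scatter), and this change can be traced to that one stereocentre: the fact that compounds 1 and 4 differ only in the configuration as drawn. The oxolan-2-yl group therefore accounts for less than the earlier step suggested. With the favourable configuration as in compound 4, exchanging the larger group for 1-(hydroxymethyl)ethyl gives only a 3.1-fold higher number from compound 2 to compound 4 (0.50 log units; beyond the scatter).

The effect of the ring-bearing group in compound 3 remains unsettled, since its entries disagree and its stereocentres are not defined: the several entries of compound 3 in this assay, 1010 nM; 15 nM (2 entries). From the compounds shown here alone, it is also open whether an amine or a carboxylic acid in place of the hydroxyl, or a longer chain at this aromatic carbon, would keep the number as low as that of compound 2.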